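Swapping the Aryl Group on a Carbamate

The source may report more compounds than this note shows. Statements on the series, on what has been measured and on what is new or still open speak of the compounds shown alone.

Measured so far:
compound 1, `CCOc1cc(=O)n(CCCO)c2c1CC(CC=C(C)C)C(C)(C)C2`: 16.6%
compound 2, `COc1ccccc1NC(=O)Oc1cc(=O)n(CCCO)c2c1CC(CC=C(C)C)C(C)(C)C2`: 0%

Both compounds were tested in a functional assay on PANC-1 cells (Homo sapiens) for inhibition, read by MTT assay, with a stated time of 24 h, tested at 10 uM; a lower number here means less inhibition, a higher number more inhibition at the concentration tested (going by the name of the read-out). Compound 1 gives 16.6%. Compound 2 gives 0%, which is the lowest of the two numbers shown, and the step of a number 16.6 percentage points lower from compound 1 to compound 2 (beyond the scatter) describes that difference. Compound 3, `CC(C)=CCC1Cc2c(OC(=O)Nc3ccc(F)cc3)cc(=O)n(CCCO)c2CC1(C)C`, has not yet been measured. It differs from compound 2 in one place: 4-fluorophenyl in place of 2-methoxyphenyl on an amide-type nitrogen. Among the compounds with values here, the only measured step, a number 16.6 percentage points lower from compound 1 to compound 2 (beyond the scatter), concerns a different change, a (2-methoxyphenyl)carbamoyl in place of ethyl on an oxygen on an aromatic ring, so no measured step bears directly on the exchange of one aryl group for another on the amide-type nitrogen. Without a guide, the expectation is a step no larger than the scatter: a number 5 percentage points higher from compound 2 to compound 3 (within the scatter). Compound 3 is therefore estimated at 5%, with a range from 0% to 20%.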

Compound 3, a percentage reported as inhibition, at one concentration (the size of the read-out at that concentration, not a potency): 0%
Compound 3: the middle estimate sits 5 percentage points above what was measured; the measured number falls inside the stated range.
By their numbers in this assay, from the lowest: compounds 2 and 3 (each within the scatter of the next); then compound 1.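

Within the data shown here, compound 3 gives the first measured exchange of one aryl group for another on the amide-type nitrogen: in this assay, the step is no change at the digits printed from compound 2 to compound 3 (within the scatter). The drop seen with the 2-methoxyphenyl carbamate is therefore not confined to that group, as (4-fluorophenyl)carbamoyl in place of ethyl on the oxygen also gives a number 16.6 percentage points lower from compound 1 to compound 3 (beyond the scatter), though this rests on only these two aryl groups. No accompanying measurement offers an explanation for either step.

As far as these compounds go, it remains open whether a non-aryl group on this nitrogen, such as a methyl or a longer alkyl chain, would give a different reading. Also open, from the compounds shown here alone, is how a longer ether chain, such as butoxy, would compare with the ethyl of compound 1 on the same oxygen.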